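Swapping Nitro for Methyl on a Cytotoxic Compound

A few compounds are considered here, and "the series" means these few. Any claim that something is new, unique, unknown or untested is made for them only; others in the source may bear on it.

So far, three related compounds have been tested in a functional assay on HCC827 cells (Homo sapiens) for cytotoxicity, read by MTT assay, with a stated time of 72 h; a lower number here means a stronger inhibitor, a higher number a weaker inhibitor. Compound 1 (`CN1CCN(c2ccc(Nc3ncc4nc(Nc5ccccc5)n(-c5ccccc5)c4n3)cc2)CC1`) gives 1.7 nM on these cells, and compound 2 (`CC1CCN(c2ccc(Nc3ncc4nc(Nc5ccccc5)n(C5CCCC5)c4n3)cc2)CC1`) gives 32 nM on the same cells. Compound 3 (`CN1CCN(c2ccc(Nc3ncc4nc(Nc5cccc([N+](=O)[O-])c5)n(C5CCCC5)c4n3)cc2)CC1`) gives < 0.01 nM as its result, which is a limit of this assay and not a number. Its standing on the numbers shown therefore rests on that limit alone (the limit of < 0.01 nM in this assay, at which 1 of the 3 values shown sits).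

Compound 4 (`Cc1cccc(Nc2nc3cnc(Nc4ccc(N5CCN(C)CC5)cc4)nc3n2C2CCCC2)c1`) has not yet been measured. It keeps all of compound 3 except one group, with methyl in place of nitro on an aromatic carbon. Going by the values given here, no measured pair of compounds differs in just one place, so no direct step can serve as a guide. Compound 1 also lacks nitro and reads 1.7 nM on these cells, which gives the main reason to expect a weaker result once nitro leaves. The expected step of an at least 50-fold higher number from compound 3 to compound 4 (1.69 log units; beyond the scatter) in this assay is large, beyond the scatter, and runs towards a weaker inhibitor. For compound 4 the estimate is 0.5 nM as the expected value, with an expected range from 0.02 nM to 10 nM around it.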

Compound 4, half-maximal inhibitory concentration: < 0.01 nM
Compound 4: a limit, no number (the forecaster's own chance of this, stated with the estimate: 15%); middle value at least 50-fold (1.69 log units) from the limit.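

In this assay compound 4 gives < 0.01 nM, which is a limit and not a number. Compound 3 rests on the same limit, so no step can be read between compound 3 and compound 4: the limit of < 0.01 nM in this assay, at which 2 of the 4 values shown sit.

The compounds shown leave open how much methyl in place of nitro changes the result.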